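This account rests on a few compounds, and the source may have more. Where it says the series, first, only, none or still open, it means among the compounds named here.

Among the measured compounds shown here, in a functional assay on ileum (Cavia porcellus) for antagonist activity (a higher number here means a weaker inhibitor, a lower number a stronger inhibitor), compound 2 `CCCc1ccccc1OCC(O)COc1ccc2c(O)c([N+](=O)[O-])c(=O)oc2c1` gives 110 nM, the lowest number so far. Compound 3 `CCCc1cc(C(C)=O)ccc1OCC(O)COc1ccc2c(O)c([N+](=O)[O-])c(=O)oc2c1` gives 700 nM. Compound 1 `O=C(O)c1ccc(OCC(O)COc2ccc3c(O)c([N+](=O)[O-])c(=O)oc3c2)cc1` reads > 10000 nM, which is a limit of the assay and not a number. Compound 4 `CC(=O)c1ccc(OCC(O)COc2ccc3c(O)c([N+](=O)[O-])c(=O)oc3c2)cc1O` differs from compound 2 in one place: 4-acetyl-3-hydroxyphenyl in place of 2-propylphenyl on an oxygen on a saturated carbon, with 4-acetyl-3-hydroxyphenyl in place of 2-propylphenyl. For the measured compounds named here, two measured steps bear on this. Adding acetyl gave the modest 6.4-fold higher number from compound 2 to compound 3 (0.80 log units; beyond the scatter), and putting 2-propylphenyl in place of 4-carboxyphenyl gave the large at least 90-fold lower number from compound 1 to compound 2 (1.95 log units; beyond the scatter). Compound 4 carries an acetyl and no propyl, so a clear rise in this assay is expected, somewhat larger than the acetyl step. The expected move is a 14-fold higher number from compound 2 to compound 4 (1.13 log units; beyond the scatter). For compound 4 the estimate is 1500 nM, with an expected range from 300 nM to 8000 nM.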

Compound 4, half-maximal inhibitory concentration: > 20000 nM
Compound 4: only a limit was reported; the forecaster's own chance of this, stated with the estimate: 15%; middle value at least 13-fold (1.12 log units) away from the limit.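

Putting 4-acetyl-3-hydroxyphenyl in place of 2-propylphenyl on this oxygen gives an at least 180-fold higher number from compound 2 to compound 4 (2.25 log units; beyond the scatter) in this assay, so a large loss here does not require the carboxylic acid of compound 1. The reading for compound 4 is a limit and not a number: the limit of > 20000 nM in this assay, at which 1 of the 4 values shown sits. The step from compound 1 to compound 4 joins two limits and cannot be read.

On these data alone, it stays open whether the acetyl, the hydroxyl or the missing propyl carries this loss. As far as these compounds go, it also stays open how a longer chain or an amine in place of the propyl would read.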